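Furan to Thiophene Swap on Octyl and Octadecyl Amides

The source may hold more compounds than are shown below. What is called first, only, known or untested is meant among the compounds shown, and "the series" means these compounds.

The set rests on compound 1 `CCCCCCCCNC(=O)[C@@H](NC(=O)c1ccco1)[C@@H](C)O`, in which a furan-2-yl carbonyl is bound to the amide nitrogen of the shared core. In a functional assay on A-431 cells (Homo sapiens) for cytotoxicity, read by MTT assay, with a stated time of 48 h (a lower number here means a stronger inhibitor, a higher number a weaker inhibitor), compound 1 gives 64500 nM. Compound 2 `CCCCCCCCNC(=O)[C@@H](NC(=O)c1cccs1)[C@@H](C)O` differs from it by thiophen-2-yl in place of furan-2-yl on a carbonyl carbon; in this assay compound 2 gives 32200 nM, which is a step of a 2.0-fold lower number from compound 1 to compound 2 (0.30 log units; within the scatter). Compound 3 `CCCCCCCCCCCCCCCCCCNC(=O)[C@@H](NC(=O)c1ccco1)[C@@H](C)O` differs from compound 1 by decyl in place of hydrogen on a saturated chain carbon, eight bonds along the chain from an amide-type nitrogen, and this is the whole difference between the two cores; in this assay compound 3 gives 19900 nM, a step of a 3.2-fold lower number from compound 1 to compound 3 (0.51 log units; beyond the scatter).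

Compound 4 `CCCCCCCCCCCCCCCCCCNC(=O)[C@@H](NC(=O)c1cccs1)[C@@H](C)O` has not yet been measured in this assay. It differs from compound 3 by thiophen-2-yl in place of furan-2-yl on a carbonyl carbon, the same change that separates compound 2 from compound 1, made at the same place, and it occurs twice among the four compounds with one measured instance. Because that measured instance reads a 2.0-fold lower number from compound 1 to compound 2 (0.30 log units; within the scatter), a step of about the same size is expected on the core of compound 3, the two cores differing only in the chain. The step of a 1.8-fold lower number from compound 3 to compound 4 (0.26 log units; within the scatter) is therefore expected, set beside a 2.0-fold lower number from compound 1 to compound 2 (0.30 log units; within the scatter). Compound 4 is accordingly estimated to give 11000 nM, with a plausible range from 5500 nM to 24000 nM.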

Compound 4, half-maximal inhibitory concentration: 33300 nM
Compound 4: the middle estimate sits 3.0-fold (0.48 log units) below what was measured, outside the stated range (above it).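

In this assay, thiophen-2-yl in place of furan-2-yl on the core of compound 3 gives a 1.7-fold higher number from compound 3 to compound 4 (0.22 log units; within the scatter), and decyl in place of hydrogen on the chain of compound 2 gives a 1.0-fold higher number from compound 2 to compound 4 (0.01 log units; within the scatter). Each of these steps lies within the scatter taken alone, but the thiophen-2-yl change did not carry from the core of compound 1 to the core of compound 3 at one size: the same change on two cores in this assay, a 2.0-fold lower number (0.30 log units; within the scatter) from compound 1 to compound 2 and a 1.7-fold higher number (0.22 log units; within the scatter) from compound 3 to compound 4, 3.4-fold (0.53 log units) apart, beyond the scatter of two such steps The decyl change likewise did not carry from one core to the other at one size, but these two comparisons rest on the same four compounds, so they show that the two changes do not simply add here and do not show a rule for the wider series or why the steps differ: the same change on two cores in this assay, a 3.2-fold lower number (0.51 log units; beyond the scatter) from compound 1 to compound 3 and a 1.0-fold higher number (0.01 log units; within the scatter) from compound 2 to compound 4, 3.4-fold (0.53 log units) apart, beyond the scatter of two such steps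

The compounds shown leave open whether the thiophen-2-yl change would behave the same way on a chain of another length, such as dodecyl, which would show where between the two chains shown its step departs from the first reading. They also leave open how other groups on the carbonyl carbon, such as phenyl or pyridin-2-yl, would read on these two cores.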